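The compounds below may be only part of what the source reports. "The series", "measured", "known", "first", "only" and "open" are said of these compounds alone.

Compounds measured so far:
- compound 1 `CN(c1ccc(C(F)(F)F)cc1)c1nc(=O)c2cccnc2s1`: 2000 nM
- compound 2 `Cc1ccc(N(C)c2nc(=O)c3cccnc3s2)cc1`: 10000 nM
- compound 3 `CN(c1ccc(F)cc1)c1nc(=O)c2cccnc2s1`: 7200 nM

All three values come from a functional assay on cells (Neuron, Rattus norvegicus) for inhibition, read by LDH release, with a stated time of 24 h; on this read-out higher numbers stand for weaker inhibition and lower numbers for stronger inhibition. Compound 3, at 7200 nM, cannot be separated from compound 2, with a 1.4-fold lower number from compound 2 to compound 3 (0.14 log units; within the scatter). Both stand clear of compound 1, which has the lowest number of the three. The steps from it are a 5.0-fold higher number from compound 1 to compound 2 (0.70 log units; beyond the scatter) and a 3.6-fold higher number from compound 1 to compound 3 (0.56 log units; beyond the scatter).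

Next is compound 4 `CN(c1ccc(OC(F)(F)F)cc1)c1nc(=O)c2cccnc2s1`, with trifluoromethoxy in place of fluoro on an aromatic carbon, para to a large group: trifluoromethoxy in place of fluoro on an aromatic carbon. For the measured compounds named here, no measured compound carries trifluoromethoxy, so any reading is by analogy. The closest measured step is the one between the trifluoromethyl of compound 1 and the fluoro of compound 3, a 3.6-fold higher number from compound 1 to compound 3 (0.56 log units; beyond the scatter). Read in reverse, it points to a lower number on leaving fluoro. The exchange of methyl and fluoro, a 1.4-fold lower number from compound 2 to compound 3 (0.14 log units; within the scatter), adds little beyond showing that not every change at this place moves the number. Going by the values given here, a modest step is therefore expected, no larger than about the one seen with compound 1, and the analogy is a single pair. The estimated change is a 2.4-fold lower number from compound 3 to compound 4 (0.38 log units; beyond the scatter). The estimate for compound 4 is 3000 nM, with an expected range of 1200 nM to 8000 nM.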

Compound 4, half-maximal inhibitory concentration: 2100 nM
Compound 4: middle estimate off by 1.4-fold (0.15 log units), on the high side, within the range that was stated.
By their numbers in this assay, from the lowest: compounds 1 and 4 (each within the scatter of the next); then compounds 3 and 2 (each within the scatter of the next).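

In this assay, replacing fluoro with trifluoromethoxy gives a 3.4-fold lower number from compound 3 to compound 4 (0.54 log units; beyond the scatter), and replacing methyl with it gives a 4.8-fold lower number from compound 2 to compound 4 (0.68 log units; beyond the scatter), whereas replacing trifluoromethyl with it gives a 1.1-fold higher number from compound 1 to compound 4 (0.02 log units; within the scatter). The low number of compound 1 is therefore no longer a single case: at this place on the aromatic ring, the four compounds form two pairs, with trifluoromethyl and trifluoromethoxy in one and methyl and fluoro in the other, and none of the four goes against this split. Nothing at hand bears on why the two pairs differ.

The compounds shown vary only at this one place, so it remains open whether the two-pair split would hold with a nitrile, an amine, a carboxylic acid or a longer chain there. As far as these compounds go, it is also open whether the same exchanges would give similar steps at another place on the aromatic ring or with a change to the shared core.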